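The source may hold more compounds than are shown below. What is called first, only, known or untested is meant among the compounds shown, and "the series" means these compounds.

Cytotoxicity series, measured in an ADME assay on ECV-304 cells (Homo sapiens) for cytotoxicity, read by MTT assay, with a stated time of 72 h; on this read-out higher numbers stand for weaker inhibition and lower numbers for stronger inhibition:

- compound 1 `C=CCOc1cc(C2=C(c3cc(OC)c(OC)c(OC)c3)C(=O)C(O)C2)ccc1OC`: > 100 ug/mL (a limit of the assay, not a number)
- compound 2 `COc1ccc(OC)c(C2=C(c3cc(OC)c(OC)c(OC)c3)C(=O)CC2O[SiH2]C(C)(C)C)c1`: 6.5 ug/mL
- compound 3 `COc1ccc(C2=C(c3cc(OC)c(OC)c(OC)c3)C(=O)C(O[SiH2]C(C)(C)C)C2)cc1`: 16 ug/mL

Compound 2 gives the lower of the two true numbers in the set, and so the stronger inhibition of the pair. Compound 3, at 16 ug/mL, sits higher by more than the usual scatter. Compound 1 remains a limit, so it cannot be placed on the same scale.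

The next compound is compound 4 `COc1cc(C2=C(c3ccccc3)C(O[SiH2]C(C)(C)C)CC2=O)cc(OC)c1OC`, which has phenyl in place of 2,5-dimethoxyphenyl on a double-bonded ring carbon. Among the measured compounds shown here, no pair of measured compounds differs in one place only, so this change has no direct precedent in this assay. For the measured compounds named here, the only guide is the spread of the numbers: compound 2 at 6.5 ug/mL and compound 3 at 16 ug/mL, which differ in more than one place. A moderate move toward a higher number, meaning weaker inhibition, is expected, although a result within the scatter of compound 2 would not be surprising. The estimated change is a 2.2-fold higher number from compound 2 to compound 4 (0.33 log units; beyond the scatter). For compound 4 the expected value is 14 ug/mL, with an estimated range of 5 ug/mL to 50 ug/mL.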

Compound 4, half-maximal inhibitory concentration: > 100 ug/mL
Compound 4: no number, only a limit; the forecaster's own chance of this, stated with the estimate: 10%; at least 7.1-fold (0.85 log units) between middle value and limit.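

In this assay, among the compounds shown here, this is the first step with a single change, and it shows that the group on the double-bonded ring carbon matters: phenyl in place of 2,5-dimethoxyphenyl gives an at least 15-fold higher number from compound 2 to compound 4 (1.18 log units; beyond the scatter), a large step beyond the scatter. Compound 4 reads > 100 ug/mL, which is a limit of the assay and not a number. The loss of inhibition in this assay is therefore clear for this pair, but the true size of the step stays unknown, because the reading of compound 4 ends at a limit: the limit of > 100 ug/mL in this assay, at which 2 of the 4 values shown sit.

Open, on these data alone, is which part of the 2,5-dimethoxyphenyl group carries the difference, and whether a phenyl with a single methoxy group on this ring carbon would bring back a true number in this assay. Also open, as far as these compounds go, is how an amine or a fluorine on that phenyl would read, and whether the same step would hold on a core with a different group on the other ring carbons.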